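The compounds below may be only part of what the source reports. "The series", "measured", "known", "first", "only" and "open" are said of these compounds alone.

Compound 1 `CCOC(=O)c1c(C)[nH]c(=O)c(C#N)c1-c1ccc(C#N)cc1` gives 9320 nM in a functional assay on MCF7 cells (Homo sapiens) for inhibition, read by MTT assay, with a stated time of 24 h; a higher number here means a weaker inhibitor, a lower number a stronger inhibitor. Compound 2 `CCOC(=O)c1c(C)[nH]c(=O)c(C#N)c1-c1ccc(F)cc1` gives 22900 nM in this assay.

Going by the values given here, compound 2 carries the highest number of the two; its nearest neighbour is compound 1, separated by the single measured step of a 2.5-fold higher number from compound 1 to compound 2 (0.39 log units; beyond the scatter). Compound 3 `CCOC(=O)c1c(C)[nH]c(=O)c(C#N)c1-c1ccc(Br)cc1` is reached from compound 2 by bromo in place of fluoro on an aromatic carbon. Among the compounds with values here, no measured step covers bromo in place of fluoro; the one step shows only that exchanging the group on this aromatic carbon moves the number modestly. Compound 3 is therefore expected near compound 2, with a 1.5-fold lower number from compound 2 to compound 3 (0.18 log units; within the scatter) as the estimated step. Compound 3 is estimated at 15000 nM, between 5000 nM and 45000 nM.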

Compound 3, half-maximal inhibitory concentration: 31800 nM
Beside the measured number, compound 3's estimate is 2.1-fold (0.33 log units) below it; low and high end bracket the measured number.
By their numbers in this assay, from the lowest: compound 1; then compounds 2 and 3 (each within the scatter of the next).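

In this assay, changing fluoro to bromo on this aromatic carbon gives a 1.4-fold higher number from compound 2 to compound 3 (0.14 log units; within the scatter) and so does not separate the two halogens. Replacing the cyano group with bromo gives a 3.4-fold higher number from compound 1 to compound 3 (0.53 log units; beyond the scatter) and leaves compound 1, with its cyano group, with the lowest number of the three. No evidence given here accounts for these results.

The compounds shown leave open whether chloro would fall with fluoro and bromo on this carbon. They also leave open whether an amine or a carboxylic acid there would give a number lower than that of compound 1.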